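A few compounds are considered here, and "the series" means these few. Any claim that something is new, unique, unknown or untested is made for them only; others in the source may bear on it.

The shared core carries a chlorine on one ring and an ether oxygen on the other, and only the group hanging from that oxygen changes. Compound 1 `CCOc1ccc2c(Cl)ccnc2c1` bears a plain ethyl chain there; in a functional assay on RKO cells (Homo sapiens) for cytotoxicity, read by MTT assay, with a stated time of 48 h (on this read-out higher numbers stand for weaker inhibition and lower numbers for stronger inhibition), compound 1 gives 3870 nM. Going by the values given here, compound 2 `Clc1ccnc2cc(OCCCc3ccccc3)ccc12` extends that chain with a benzyl group; in this assay compound 2 gives 1420 nM, which is the lowest of the two numbers so far, and the step of a 2.7-fold lower number from compound 1 to compound 2 (0.44 log units; beyond the scatter) is the only measured change bearing on this position. Compound 3 `Clc1ccnc2cc(OCCc3ccccc3)ccc12` is the next step: phenyl in place of benzyl on a saturated chain carbon, two bonds along the chain from an oxygen on an aromatic ring. The phenyl ring is kept, but the chain between it and the oxygen is one carbon shorter. Among the compounds with values here, the single relevant step shows that placing a phenyl ring at the end of this chain lowers the number modestly, yet no measured pair tells how much chain length matters. The estimate for compound 3 is therefore a small shift back toward compound 1, within the scatter, as the step of a 1.4-fold higher number from compound 2 to compound 3 (0.15 log units; within the scatter), putting compound 3 at an expected 2000 nM, with a likely range from 900 nM to 4500 nM.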

Compound 3, half-maximal inhibitory concentration: 2560 nM
Compound 3: the middle estimate sits 1.3-fold (0.11 log units) below what was measured; measured number inside the range.
By their numbers in this assay, from the lowest: compounds 2, 3 and 1 (each within the scatter of the next, the first and the last beyond it).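

In this assay, shortening the chain by one carbon gives a 1.8-fold higher number from compound 2 to compound 3 (0.26 log units; within the scatter), so the data cannot separate these two chain lengths. Compared with the plain ethyl chain, the phenyl ring on the shorter chain gives a 1.5-fold lower number from compound 1 to compound 3 (0.18 log units; within the scatter), whereas the longer chain gave a 2.7-fold lower number from compound 1 to compound 2 (0.44 log units; beyond the scatter), so only compound 2 stands clearly apart from compound 1, and only by a modest margin. No supporting measurement is available to explain these numbers.

With a gap this small, the three compounds show no reliable trend with chain length, and a longer chain ending in a phenyl ring would be needed to test whether the number keeps falling as the chain grows. They also leave open how this position responds to a group of a different kind at the end of the chain, such as an amine or a carboxylic acid, and whether the chlorine on the shared core contributes to the cytotoxicity at all.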